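A few compounds are considered here, and "the series" means these few. Any claim that something is new, unique, unknown or untested is made for them only; others in the source may bear on it.

Within the data shown here, compound 2 `Cc1ccccc1-c1nnc(N(N)C(C)C)s1` is the only member of the series that returns a number in a functional assay on the whole organism with Mus musculus as the target, in the maximal electroshock model, with a stated time of 1 h; a higher number here means that more compound is needed for the effect, a lower number that less compound is needed: compound 2 gives 54 mg/kg. Compound 1 `Cc1ccccc1-c1nnc(NN)s1` gives only a limit of the assay, > 100 mg/kg. Compound 3 `CC(C)N(N)c1nnc(-c2ccccc2-c2ccccc2)s1` likewise gives only a limit, > 100 mg/kg. Two of the three results therefore sit at the limit of > 100 mg/kg in this assay, at which 2 of the 3 values shown sit. The step of an at least 1.8-fold lower number from compound 1 to compound 2 (0.26 log units; that floor lies within the scatter) puts the isopropyl onto the hydrazine nitrogen; the step of an at least 1.8-fold higher number from compound 2 to compound 3 (0.26 log units; that floor lies within the scatter) exchanges the aryl substituent. Compound 4 `Cc1ccccc1-c1nnc(NNC(C)C)s1` is not yet measured. The change is (isopropylamino)amino in place of amino(isopropyl)amino on an aromatic carbon. Among the measured compounds shown here, only the step from compound 1 to compound 2 concerns the same isopropyl, and it is an addition rather than a relocation, with its floor inside the scatter. No step beyond the scatter is therefore expected, a 1.1-fold higher number from compound 2 to compound 4 (0.05 log units; within the scatter). Compound 4 is expected to give about 60 mg/kg in this assay, within 25 mg/kg to 150 mg/kg.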

Compound 4, dose for half-maximal effect: 83 mg/kg
Compound 4: the middle estimate sits 1.4-fold (0.14 log units) below what was measured; the range from low to high includes it.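

In this assay, the exchange of amino(isopropyl)amino for (isopropylamino)amino on the aromatic carbon gives a 1.5-fold higher number from compound 2 to compound 4 (0.19 log units; within the scatter), so compound 2 and compound 4 cannot be told apart. Compound 4 thus adds a second number to the series, with the isopropyl on the other nitrogen. The step of an at least 1.2-fold lower number from compound 1 to compound 4 (0.08 log units; that floor lies within the scatter) starts from a limit and gives only a floor for adding the isopropyl on that amine nitrogen.

Open, on these data alone, is whether a longer chain or a cyclopropyl on either nitrogen still gives a number in this assay. Any step that starts or ends at a limit stays a floor: the limit of > 100 mg/kg in this assay, at which 2 of the 4 values shown sit.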